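This account rests on a few compounds, and the source may have more. Where it says the series, first, only, none or still open, it means among the compounds named here.

Compound 1, `CCN(Cc1ccccc1)c1cc(C)nc(N(CC)c2ccc(C(C)C)cc2Br)n1`: 17 nM
Compound 2, `CCCCN(Cc1nn[nH]n1)c1cc(C)nc(N(CC)c2ccc(C(C)C)cc2Br)n1`: > 1000 nM
Compound 3, `CCN(c1ccc(C(C)C)cc1)c1nc(C)cc(C)n1`: > 1000 nM

All three compounds were tested in an assay on isolated protein for binding affinity to corticotropin-releasing factor receptor 1 (Homo sapiens); a higher number here means a weaker inhibitor, a lower number a stronger inhibitor. Compound 1 is the only one with a numerical result, 17 nM. For compound 2 the assay reports only a limit, not a number. For compound 3 likewise only a limit is known, so it stands at the weak end of what has been measured and its true affinity cannot be placed more precisely than that. Two of the three results thus sit at the limit of > 1000 nM in this assay, at which 2 of the 3 values shown sit.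

Compound 4, `CCN(c1nc(C)cc(C)n1)c1ccc(C(C)C)cc1SC`, differs from compound 3 in one place: methylsulfanyl in place of hydrogen on an aromatic carbon. Among the compounds with values here, no pair of measured compounds differs in exactly this way, so the size of this step has not been observed. Compound 1, which carries groups that compound 3 lacks and gives a measurable number, suggests that substitution around this part of the molecule can matter, but compound 1 differs from compound 3 in more than one place and cannot settle the question.

The step from compound 3 to compound 4 is expected to be an at least 3.3-fold lower number from compound 3 to compound 4 (0.52 log units; beyond the scatter), toward stronger binding, though compound 3 offers only a limit as the starting point. Compound 4 is estimated at 300 nM, in a range from 40 nM to 3000 nM.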

Compound 4, inhibition constant: 36 nM
Estimate against measurement, compound 4: 8.3-fold (0.92 log units) above, outside the stated range (below it).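

In this assay, methylsulfanyl in place of hydrogen on this aromatic carbon, ortho to a large group and meta to an isopropyl group, gives an at least 27-fold lower number from compound 3 to compound 4 (1.44 log units; beyond the scatter), which means stronger binding and shows that this one position alone can carry a large change. The earlier compounds shown here could not show this, since compound 1 and compound 3 differ in more than one place. The step has only a lower bound on its size and its true size stays unknown, because compound 3 is recorded as a limit and not as a number: the limit of > 1000 nM in this assay, at which 2 of the 4 values shown sit.

On these data alone, it remains open whether this gain is particular to methylsulfanyl or would also come with another group on the same carbon, such as methoxy, an amine or the longer ethylsulfanyl chain. As far as these compounds go, it is equally open whether the step would keep its size in a compound built like compound 1, whose ring carrying the isopropyl group also holds a bromine.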